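A few compounds are considered here, and "the series" means these few. Any claim that something is new, unique, unknown or untested is made for them only; others in the source may bear on it.

Compound 1 `CC(O)(COc1ccc(S(F)(F)(F)(F)F)cc1)C(=O)Nc1ccc(C#N)cc1C(F)(F)F` and compound 2 `CC(O)(COc1ccc(S(F)(F)(F)(F)F)cc1)C(=O)Nc1ccc([N+](=O)[O-])cc1C(F)(F)F` share a core and differ in one group only, (nitro in place of cyano on an aromatic carbon). In a functional assay on DU-145 cells (Homo sapiens) for antiproliferative activity, read by propidium iodide staining, with a stated time of 96 h (a lower number here means a stronger inhibitor, a higher number a weaker inhibitor), compound 1 gives 16000 nM. In this assay compound 2 gives 15400 nM. That change made a 1.0-fold lower number from compound 1 to compound 2 (0.02 log units; within the scatter). Compound 3 `CC(O)(CS(=O)(=O)c1cccc(S(F)(F)(F)(F)F)c1)C(=O)Nc1ccc(C#N)cc1C(F)(F)F` is built on a different core; how the two cores differ is not broken down here. In this assay compound 3 gives 22100 nM, a number that lies within the scatter of both compound 1 and compound 2. Compound 4 `CC(O)(CS(=O)(=O)c1cccc(S(F)(F)(F)(F)F)c1)C(=O)Nc1ccc([N+](=O)[O-])cc1C(F)(F)F` has not yet been measured. It arises from compound 3 by the same change already seen between compound 1 and compound 2, (nitro in place of cyano on an aromatic carbon), and the surroundings of the change read the same in both pairs. Because that earlier change gave a 1.0-fold lower number from compound 1 to compound 2 (0.02 log units; within the scatter), a step of about the same size is expected here, a 1.1-fold lower number from compound 3 to compound 4 (0.02 log units; within the scatter). Compound 4 is therefore estimated to give 21000 nM in this assay, with a likely range from 11000 nM to 42000 nM, an expectation that rests on a single earlier pair and so carries real uncertainty.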

Compound 4, half-maximal inhibitory concentration: 100000 nM
For compound 4 the middle estimate is 4.8-fold (0.68 log units) below the measured one; the measured number lies above the stated range.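

In this assay, putting nitro in place of cyano on the core of compound 3 gave a 4.5-fold higher number from compound 3 to compound 4 (0.66 log units; beyond the scatter), so compound 4 is the weaker inhibitor of this pair. The change therefore did not carry over at the same size from one core to the other, and its effect in this series depends on the core that carries it: the same change on two cores in this assay, a 1.0-fold lower number (0.02 log units; within the scatter) from compound 1 to compound 2 and a 4.5-fold higher number (0.66 log units; beyond the scatter) from compound 3 to compound 4, 4.7-fold (0.67 log units) apart, beyond the scatter of two such steps This does not show which difference between the two cores lies behind the gap, and two pairs cannot set a rule for any third core.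

The compounds shown leave open how a chlorine atom, an amine or a carboxylic acid in place of the cyano or nitro group would read on either core. They also leave open whether a thioether link in the chain, in place of the ether of compound 1 and the sulfone of compound 3, would follow one core or the other.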